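The source may report more compounds than this note shows. Statements on the series, on what has been measured and on what is new or still open speak of the compounds shown alone.

Measured so far in a functional assay on HT-29 cells (Homo sapiens) for cytotoxicity, read by sulforhodamine B assay, with a stated time of 48 h; on this read-out lower numbers stand for stronger inhibition of growth and higher numbers for weaker inhibition of growth:
Compound 1, `COc1cc(C(=O)c2c[nH]c3cccc(OC)c23)c(N)c(OC)c1OC`: in this assay compound 1 gives > 100000 nM, which is a limit of the assay and not a number.
Compound 2, `COc1cc(C(=O)c2c[nH]c3c(OC)cccc23)c(N)c(OC)c1OC`: in this assay compound 2 gives 48600 nM.
Compound 3, `COC(=O)c1[nH]c2ccccc2c1C(=O)c1cc(OC)c(OC)c(OC)c1N`: in this assay compound 3 gives 2380 nM.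

Of the two values that are numbers, compound 3 stands lowest; compound 2 gives a higher number, and that gap lies beyond the usual scatter, so compound 3 is the stronger inhibitor of growth of the two. Compound 1 is known only through (the limit of > 100000 nM in this assay, at which 1 of the 3 values shown sits).

Compound 4, `COC(=O)c1[nH]c2ccc(Br)cc2c1C(=O)c1cc(OC)c(OC)c(OC)c1N`, has not yet been measured. It differs from compound 3 in one place: bromo in place of hydrogen on an aromatic carbon. Within the data shown here, no step between measured compounds involves a bromo, so nothing measured here shows how such a change moves the read-out. Among the measured compounds shown here, with no comparable step to draw on, a small move rather than a large one in either direction is expected, and the step from compound 3 to compound 4 is estimated at a 1.3-fold higher number from compound 3 to compound 4 (0.10 log units; within the scatter). Compound 4 is therefore estimated at 3000 nM, with a range from 700 nM to 13000 nM.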

Compound 4, concentration for 50% growth inhibition: 1940 nM
Beside the measured number, compound 4's estimate is 1.5-fold (0.19 log units) above it; the range from low to high includes it.
By their numbers in this assay, from the lowest: compounds 4 and 3 (each within the scatter of the next); then compound 2. At a limit, above all of these: compound 1.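

Bromo in place of hydrogen on an aromatic carbon gives a 1.2-fold lower number from compound 3 to compound 4 (0.09 log units; within the scatter) in this assay and so, for the first time here, a substituent has been read on this six-membered ring of the shared core. At this place, meta to a fused ring and para to a fused ring, a single bromine atom leaves compound 4 indistinguishable from compound 3 in this read-out. Nothing measured here bears on why the two compounds read alike.

The compounds shown leave open whether a nitrile, a carboxylic acid or a longer alkyl chain at the same carbon would also read like compound 3 or would separate from it beyond the scatter. They also leave open how bromo would read on the other carbons of this ring.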